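This account rests on a few compounds, and the source may have more. Where it says the series, first, only, none or still open, it means among the compounds named here.

Measured so far in a functional assay on NALM-6 cells (Homo sapiens) for cytotoxicity, with a stated time of 72 h; a lower number here means that less compound is needed, a higher number that more compound is needed for the effect:
Compound 1 `C=C[C@](C)(CCCC(C)C)CCc1ccc(O)cc1` gives 27500 nM.
Compound 2 `C=C[C@@](C)(/C=C/c1ccc(O)c(/C=C/C(=O)c2ccccc2)c1)CCC=C(C)C` gives 4470 nM.
Compound 3 `C=C[C@@](C)(/C=C/c1ccc(O)c(/C=C/C(=O)NCc2ccc(C(F)(F)F)cc2)c1)CCC=C(C)C` gives > 43400 nM, which is a limit of the assay rather than a number.

Of the two numbers, compound 2 stands lowest; the nearest number is that of compound 1, and that gap lies beyond the usual scatter. Compound 4 `C=C[C@@](C)(/C=C/c1ccc(O)c(/C=C/C=C/c2ccccc2)c1)CCC=C(C)C` is not yet measured. Its change from compound 2 is 2-phenylethenyl in place of benzoyl on a double-bonded chain carbon bound to a double-bonded chain carbon. For the measured compounds named here, no step between measured compounds stands here to lean on, so the expectation rests on the structures alone. Compound 4 is expected to need more in this assay, a step estimated as a 2.7-fold higher number from compound 2 to compound 4 (0.43 log units; beyond the scatter), beyond the scatter yet short of the limit. The estimate for compound 4 is 12000 nM, within 3000 nM to 40000 nM.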

Compound 4, half-maximal effective concentration: > 43400 nM
Compound 4: no number, only a limit (the forecaster's own chance of this, stated with the estimate: 25%); middle value at least 3.6-fold (0.55 log units) away from the limit.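

In this assay, 2-phenylethenyl in place of benzoyl on a double-bonded chain carbon bound to a double-bonded chain carbon gives an at least 9.7-fold higher number from compound 2 to compound 4 (0.98 log units; beyond the scatter). The two groups have equal heavy-atom counts and the same kind of aromatic ring, yet the one that enters lacks the oxygen and its hydrogen-bond acceptor, showing that matching size alone does not preserve the effect here. Compound 4 gives only a limit of the assay, not a number, so the full step stays unknown: the limit of > 43400 nM in this assay, at which 2 of the 4 values shown sit.

Whether the carbonyl oxygen itself accounts for this step remains open. Also open, as far as these compounds go, is how acetyl, which keeps the carbonyl but has no phenyl ring, would read at this place.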